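The source may report more compounds than this note shows. Statements on the series, on what has been measured and on what is new or still open speak of the compounds shown alone.

Measured so far in an ADME assay on J774.1 cells (Mus musculus) for cytotoxicity, with a stated time of 48 h; a lower number here means that less compound is needed, a higher number that more compound is needed for the effect:

compound 1 `COC(=O)C1C(=O)C(C(=O)OC)[C@H](c2ccccn2)N(CCCCCCCC(=O)O)[C@@H]1c1ccccn1`: 33.8 uM
compound 2 `COC(=O)C1C(=O)C(C(=O)OC)[C@H](c2ccccn2)N(Cc2ccccn2)[C@@H]1c1ccccn1`: 29.9 uM
compound 3 `C=CCN1[C@H](c2ccccn2)C(C(=O)OC)C(=O)C(C(=O)OC)[C@@H]1c1ccccn1`: > 100 uM

The value of compound 3 is a limit of the assay and not a number; compound 3 is the only one of the three that sits at this limit (the limit of > 100 uM in this assay, at which 1 of the 3 values shown sits). Compounds 1 and 2 lie within the scatter of each other (a 1.1-fold lower number from compound 1 to compound 2 (0.05 log units; within the scatter)), so nothing separates them.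

Compound 4 `COC(=O)C1C(=O)C(C(=O)OC)[C@H](c2ccccn2)N(CCCO)[C@@H]1c1ccccn1` differs from compound 3 by 2-hydroxyethyl in place of vinyl on a saturated chain carbon bound to an amine nitrogen in a ring. Going by the values given here, two measured steps bear on this position, both ending at compound 3: an at least 2.9-fold higher number from compound 1 to compound 3 (0.47 log units; beyond the scatter) and an at least 3.3-fold higher number from compound 2 to compound 3 (0.52 log units; beyond the scatter). In each, a larger group on the saturated chain carbon bound to the amine nitrogen gave way to vinyl, and in each the number rose by at least a modest amount. The change to compound 4 runs the other way, from vinyl to a longer chain carrying a hydroxyl, which by that pattern would be expected to lower the number again; since compound 3 stands only at a limit, the true size of the step cannot be read from the numbers. The step from compound 3 to compound 4 is therefore expected to be an at least 1.6-fold lower number from compound 3 to compound 4 (0.22 log units; that floor lies within the scatter), with considerable uncertainty. For compound 4 the estimated value is 60 uM, within a range of 25 uM to 150 uM.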

Compound 4, concentration for half-maximal effect: 32 uM
Compound 4: the middle estimate sits 1.9-fold (0.27 log units) above what was measured, and the stated range covers the measured number.
By their numbers in this assay, from the lowest: compounds 2, 4 and 1 (each within the scatter of the next). At a limit, above all of these: compound 3.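

Going by these compounds alone, the change from allyl to 3-hydroxypropyl gives an at least 3.1-fold lower number from compound 3 to compound 4 (0.49 log units; beyond the scatter) in this assay, so a large group such as the 6-carboxyhexyl or pyridin-2-yl of the earlier compounds is not required for the lower number. The other two steps, a 1.1-fold higher number from compound 2 to compound 4 (0.03 log units; within the scatter) and a 1.1-fold lower number from compound 1 to compound 4 (0.02 log units; within the scatter), leave 2-hydroxyethyl, pyridin-2-yl and 6-carboxyhexyl on the saturated chain carbon bound to the amine nitrogen in a ring indistinguishable in this assay, and among the groups shown only vinyl stands apart. The value of compound 3 remains a limit of the assay and not a number, so the step out of it gives only a floor: the limit of > 100 uM in this assay, at which 1 of the 4 values shown sits.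

The step from compound 3 to compound 4 changes the double bond and the hydroxyl together, so the compounds shown leave open which of the two goes with the lower number. A plain propyl chain would separate these two changes, and an amine or a carboxylic acid at the end of the same short chain would show whether the hydroxyl can be replaced.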